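Halogen on the aryl ring and the inhibition in this assay

The compounds below may be only part of what the source reports. "The series", "measured", "known", "first", "only" and "open" are said of these compounds alone.

Measured so far:
compound 1 `COC(=O)C(=N)/C=C(\O)c1ccccc1` gives 3% in an assay for inhibition of kynurenine 3-monooxygenase (Rattus norvegicus), tested at 10 uM; a lower number here means less inhibition, a higher number more inhibition at the concentration tested (going by the name of the read-out)
compound 2 `COC(=O)C(=N)/C=C(\O)c1ccccc1Cl` gives 31%

Compound 1 stands lowest of the two numbers. Compound 3 `COC(=O)C(=N)/C=C(\O)c1ccc(Br)cc1` differs from it by bromo in place of hydrogen on an aromatic carbon. For the measured compounds named here, the only measured step that bears on this is a number 28 percentage points higher from compound 1 to compound 2 (beyond the scatter), also a halogen entering the same ring, though at a different place. A step of similar size in the same direction is therefore expected for compound 3, giving an estimate of 22% (range 0% to 45%), which means an expected a number 19 percentage points higher from compound 1 to compound 3 (beyond the scatter).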

Compound 3, a percentage reported as inhibition, at one concentration (the size of the read-out at that concentration, not a potency): 0%
Estimate against measurement, compound 3: 22 percentage points above, within the range that was stated.
By their numbers in this assay, from the lowest: compounds 3 and 1 (each within the scatter of the next); then compound 2.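

In this assay, bromo on an aromatic carbon, para to a group of 9 heavy atoms, gives a number 3 percentage points lower from compound 1 to compound 3 (within the scatter). A halogen on this ring therefore does not always bring a step like a number 28 percentage points higher from compound 1 to compound 2 (beyond the scatter). Nothing available explains this result.

The compounds shown leave open whether the contrast between these two steps comes from the kind of halogen or from where it sits on the ring. From the compounds shown here alone, how an amine or a carboxylic acid at this same place would behave also remains unknown.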